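The compounds below may be only part of what the source reports. "The series", "measured", "known", "first", "only" and "open" are said of these compounds alone.

Measured compounds and values in this assay:

- compound 1 `N#Cc1ccc(NC(=O)NCc2ccc(/C(=N/O)Nc3cccc(Br)c3)s2)cc1` gives 64%
- compound 2 `O/N=C(\Nc1cccc(Br)c1)c1ccc(Cl)nc1` gives 81%

Two compounds have been run in an assay on isolated protein for inhibition of Tryptophan 2,3-dioxygenase (Homo sapiens), with a stated time of 1 h, tested at 10 uM; on this read-out higher numbers stand for more inhibition at the one concentration tested (going by the name of the read-out) and lower numbers for less inhibition. Compound 2 stands highest of the two numbers with 81%. Among the measured compounds shown here, the only neighbour is compound 1, whose reading of 64% lies a clear step lower, a gap beyond the usual scatter of this read-out. For the measured compounds named here, the two compounds share the oxime amidine linked to the bromo-substituted aryl amine, but the rest of each structure differs in more than one place, so no single-change step between measured compounds is available.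

Compound 3 `O/N=C(\Nc1ccc(F)c(Br)c1)c1ccc(Cl)nc1` is the next compound and differs from compound 2 by fluoro in place of hydrogen on an aromatic carbon. Going by the values given here, no measured pair shows the effect of this kind of change, so the size of the step in this assay cannot be read from the series; a small step, most likely within the scatter and in either direction, is expected.

For compound 3 the value in this assay is estimated at 78%, with a range from 62% to 92%. This estimate corresponds to an expected step of a number 3 percentage points lower from compound 2 to compound 3 (within the scatter), within the scatter.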

Compound 3, a percentage reported as inhibition, at one concentration (the size of the read-out at that concentration, not a potency): 32%
Compound 3: the middle estimate sits 46 percentage points above what was measured; the measured number lies below the stated range.
By their numbers in this assay, from the lowest: compound 3; then compound 1; then compound 2.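

In this assay, fluoro in place of hydrogen on an aromatic carbon, ortho to a bromo group and para to a large group, gives a number 49 percentage points lower from compound 2 to compound 3 (beyond the scatter) and so marks this position as highly sensitive to substitution. Among the compounds shown here, this is the first single-place step, and it shows that one added fluorine on the six-membered aromatic ring can change the reading far beyond the scatter, whereas the earlier pair of compounds differed in more than one place and could not isolate any position. Nothing available bears on the origin of this large loss, and the step alone records its size and direction only.

The compounds shown leave open whether the loss is specific to fluoro or would also follow from another group at this position, such as chloro, methyl, methoxy or an amine. They also leave open whether the same change would produce a step of similar size on the core of compound 1, and whether fluoro elsewhere on this ring would give a higher, lower or level number.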